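Nitro in place of hydrogen on compound 2

This account rests on a few compounds, and the source may have more. Where it says the series, first, only, none or still open, it means among the compounds named here.

In an ADME assay on Raji cells (Homo sapiens) for cytotoxicity, with a stated time of 72 h (a lower number here means that less compound is needed, a higher number that more compound is needed for the effect), compound 1 (`Cc1cc(NC(=O)Nc2cccc(F)c2)c2ccccc2n1`) reads > 25000 nM, which is a limit of the assay. Going by the values given here, compound 2 (`Cc1cc(NC(=O)Nc2cccc(C(F)(F)F)c2)c2ccccc2n1`) gives 10000 nM, the only number so far that is not a limit. Compound 3 (`Cc1cc(NC(=O)Nc2ccc([N+](=O)[O-])c(C(F)(F)F)c2)c2ccccc2n1`) has nitro in place of hydrogen on an aromatic carbon, ortho to a trifluoromethyl group: nitro in place of hydrogen on an aromatic carbon. Among the compounds with values here, the sole measured step, an at least 2.5-fold lower number from compound 1 to compound 2 (0.39 log units; beyond the scatter), swaps a different group and is at least modest, so it bears only loosely. A modest move to a lower number in this assay is expected, as a 1.7-fold lower number from compound 2 to compound 3 (0.22 log units; within the scatter). Compound 3 is estimated at 6000 nM, with an expected range of 1500 nM to 20000 nM.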

Compound 3, half-maximal effective concentration: > 25000 nM
Compound 3 ended at the assay's limit (the forecaster's own chance of this, stated with the estimate: 10%); middle value at least 4.1-fold (0.61 log units) away from the limit.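

In this assay, going by these compounds alone, the first change at this ring carbon, para to a large group, gives an at least 2.5-fold higher number from compound 2 to compound 3 (0.39 log units; beyond the scatter). This runs opposite to an at least 2.5-fold lower number from compound 1 to compound 2 (0.39 log units; beyond the scatter), so a larger group on this aromatic ring does not lower the number in every case shown. Only a minimum for the step from hydrogen to nitro can be read: the limit of > 25000 nM in this assay, at which 2 of the 3 values shown sit.

Going by these compounds, whether an amine or a carboxylic acid on the same carbon would move the number the same way remains open. So does whether nitro gives a similar step without the trifluoromethyl group.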